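Chloro to Bromo: Expected Effect on Cell Toxicity

A few compounds are considered here, and "the series" means these few. Any claim that something is new, unique, unknown or untested is made for them only; others in the source may bear on it.

In an ADME assay on J774 cells (Mus musculus) for cytotoxicity, read by MTT assay, with a stated time of 48 h, tested at 50 ug/mL (a higher number here means a weaker effect of the compound at the concentration tested, a lower number a stronger effect), compound 1 `O=C(N/N=C/c1cccc(Cl)c1)c1cnccn1` gives 100%, while compound 2 `O=C(N/N=C/c1ccc(Cl)cc1)c1cnccn1` gives 83%, the lower of the two numbers, and its gap to compound 1 lies beyond the usual scatter. Compound 3 `O=C(N/N=C/c1ccc(Br)cc1)c1cnccn1` is not yet measured. It differs from compound 2 by bromo in place of chloro on an aromatic carbon. Among the compounds with values here, no measured pair shows this kind of change, so the expected step is a number 3 percentage points lower from compound 2 to compound 3 (within the scatter), small and without a clear direction beyond the scatter. In this assay compound 3 is estimated to give 80%, within a range from 62% to 98%.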

Compound 3, a percentage reported as activity, at one concentration (the size of the read-out at that concentration, not a potency): 100%
The estimate for compound 3 lay 20 percentage points below the measured number, outside the stated range (above it).
By their numbers in this assay, from the lowest: compound 2; then compounds 1 and 3 (each within the scatter of the next).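

At this place on the ring, para to a large group, swapping one halogen for another is not a silent change: in this assay, bromo in place of chloro brings a number 17 percentage points higher from compound 2 to compound 3 (beyond the scatter). Since a higher number means a weaker effect, compound 3 acts more weakly than compound 2 at the concentration tested. Nothing shown here explains this step. From the compounds shown here alone, whether an amine, a methoxy group or a carboxylic acid at this same place would read closer to compound 2 or to compound 3 stays open.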